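A few compounds are considered here, and "the series" means these few. Any claim that something is new, unique, unknown or untested is made for them only; others in the source may bear on it.

Notes on the series. Compound 1, `O=C1O/C(=C\Cn2cc(-c3cc(C(F)(F)F)cc(C(F)(F)F)c3)nn2)C(OCc2ccccc2)=C1OCc1ccccc1`, and compound 2, `CCCCCCCCCCc1cn(C[C@H](O)[C@H]2OC(=O)C(OCc3ccccc3)=C2OCc2ccccc2)nn1`, share the same core and differ only in the substituent on the heterocyclic ring and in the short chain linking that ring to the core. In an ADME assay on HFF cells (Homo sapiens) for cytotoxicity, read by MTT assay, with a stated time of 72 h (on this read-out higher numbers stand for weaker inhibition and lower numbers for stronger inhibition), compound 1 gives only a limit, > 100000 nM. In this assay compound 2 likewise gives only a limit, > 100000 nM. Going by the values given here, compound 2 thus stands where every value so far stands, at the limit of > 100000 nM in this assay, at which 2 of the 2 values shown sit; no measured step between the two is available, and only what the two values show can be said: neither compound reaches a measurable number within the range of this assay. Compound 3, `O=C1O[C@H]([C@@H](O)Cn2cc(CCO)nn2)C(OCc2ccccc2)=C1OCc1ccccc1`, is the next member to be measured in this assay. It differs from compound 2 by hydroxy in place of octyl on a saturated chain carbon, two bonds along the chain from an aromatic carbon. Among the compounds with values here, no step is measured for such a change, so the expectation rests on compound 2 alone: no step beyond the scatter is expected, with a step that the limit leaves unreadable from compound 2 to compound 3 taken as essentially flat, and the result is expected again to be a limit rather than a number. On that basis compound 3 is estimated at 150000 nM, within 80000 nM to 300000 nM.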

Compound 3, half-maximal inhibitory concentration: 58500 nM
Beside the measured number, compound 3's estimate is 2.6-fold (0.41 log units) above it, and the stated range ends above it.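

In this assay, compound 3 is the first member shown to read as a number rather than a limit, so the read-out can register a compound of the shared core. Hydroxy in place of octyl on a saturated chain carbon, two bonds along the chain from an aromatic carbon, gives an at least 1.7-fold lower number from compound 2 to compound 3 (0.23 log units; that floor lies within the scatter); the value of compound 2 is a limit, so the true size of this step cannot be read, and its floor alone does not establish a change beyond the scatter. The other values shown remain limits, not numbers: the limit of > 100000 nM in this assay, at which 2 of the 3 values shown sit.

The same difference also reads decyl to 2-hydroxyethyl, so the compounds shown cannot separate the loss of the long chain from the arrival of the hydroxy. Also open, on these data alone, is how an amine or a carboxylic acid in place of hydroxy on that saturated chain carbon, or hydroxy carried on a longer chain, would read in this assay.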